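Swapping the methoxyphenyl arm for a tolyl group

The compounds below may be only part of what the source reports. "The series", "measured", "known", "first", "only" and "open" are said of these compounds alone.

Measured compounds:
- compound 1 `CC[C@H](C)C(=O)O[C@H]1C[C@@H](C)C=C2C=C[C@H](C)[C@H](CC[C@@H]3C[C@@H](O)CC(=O)O3)[C@]21C` gives 3 nM in an assay on microsomes from liver for inhibition of 3-hydroxy-3-methylglutaryl-coenzyme A reductase (Rattus norvegicus); a higher number here means a weaker inhibitor, a lower number a stronger inhibitor
- compound 2 `CC[C@H](C)C(=O)O[C@H]1C[C@H](O)C=C2C=C[C@H](C)[C@H](CCC(O)C[C@H](O)CC(=O)O)[C@]21C` gives 5 nM in this assay
- compound 3 `COc1cccc(-c2nc(C(F)(F)F)n(CC[C@@H](O)C[C@@H](O)CC(=O)O)c2-c2ccc(F)cc2)c1` gives 20 nM in this assay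

Compound 3 stands with the highest number of the three, so it is the weakest inhibitor of the set; its nearest neighbour is compound 2, and the gap to compound 2 lies beyond the scatter, as does the larger gap to compound 1. Compounds 1 and 2 share a core of their own, while compound 3 is built on a different core, so nothing links the two groups by a single change.

Compound 4 `Cc1ccc(-c2nc(C(F)(F)F)n(CC[C@@H](O)C[C@@H](O)CC(=O)O)c2-c2ccc(F)cc2)cc1` is the one untested structure. It differs from compound 3 by 4-methylphenyl in place of 3-methoxyphenyl on an aromatic carbon. Both arms are plain six-membered aromatic carbon rings of closely similar size, and the rest of the molecule is untouched. Going by the values given here, no step between measured compounds mirrors this change, so there is nothing in the set that would point to a large move in either direction. In this assay compound 4 is expected to remain close to compound 3, with the step of a 1.3-fold higher number from compound 3 to compound 4 (0.10 log units; within the scatter) estimated to fall within the scatter. The estimate for compound 4 is 25 nM, within a range of 8 nM to 80 nM.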

Compound 4, half-maximal inhibitory concentration: 43 nM
The estimate for compound 4 lay 1.7-fold (0.24 log units) below the measured number, and the stated range covers the measured number.
By their numbers in this assay, from the lowest: compounds 1 and 2 (each within the scatter of the next); then compound 3; then compound 4.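

In this assay, going by these compounds alone, exchanging the 3-methoxyphenyl arm for 4-methylphenyl on the aromatic carbon gives a 2.2-fold higher number from compound 3 to compound 4 (0.33 log units; beyond the scatter), the first change in a single place that the set allows to be read. Until now, the compounds could not show whether this position responds to its arm at all; this modest step shows that it does, even though the entering and leaving arms both carry one six-membered aromatic ring of carbon only and the rest of the molecule stays the same. No measurement at hand explains the rise in the number, so the step records the size of the change and nothing about its origin.

The step combines two differences in one exchange, since the substituent on the arm and its place on that ring both change, and the compounds shown cannot separate them. A 3-methylphenyl or a 4-methoxyphenyl arm would divide the two effects, while an unsubstituted phenyl arm would show what either substituent contributes at this position.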